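The compounds below may be only part of what the source reports. "The series", "measured", "known", "first", "only" and "open" are said of these compounds alone.

The three measured compounds were tested in an assay for binding affinity to 17-beta-hydroxysteroid dehydrogenase type 2 (Homo sapiens), with a stated time of 20 min, tested at 1 uM; on this read-out lower numbers stand for less inhibition and higher numbers for more inhibition at the one concentration tested (going by the name of the read-out). Compound 1 `COc1ccncc1-c1ccc2c(O)cccc2c1` gives < 10% there, which is a limit of the assay rather than a number. Compound 2 `CN(C(=O)c1ccccc1)c1cccc(-c2ccc(CO)cc2)c1` likewise gives < 10% in this assay, again a limit and not a number. Going by the values given here, compound 3 `COc1ccc(C(=O)N(C)c2cccc(-c3ccc(CO)cc3)c2)cc1` gives 14% in this assay, the only actual number among the three results. Among the compounds with values here, the one measured step, a number at least 4 percentage points higher from compound 2 to compound 3 (that floor lies within the scatter), is the only guide available, and its size stays within the usual scatter of repeated measurements, so it shows no real change. Two of the three results sit at the limit of < 10% in this assay, at which 2 of the 3 values shown sit.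

The next compound is compound 4 `COc1ccc(C(=O)N(C)c2cccc(-c3ccc(OC)cc3)c2)cc1`. It differs from compound 3 by methoxy in place of hydroxymethyl on an aromatic carbon. Within the data shown here, no measured step involves this change; the only measured step puts methoxy in place of hydrogen on an aromatic carbon, and it was too small to tell anything. Nothing in these results points to a movement beyond the scatter in either direction. Compound 4 is therefore expected to give roughly 10% in this assay, with a range from 0% to 25%. That estimate means a step of a number 4 percentage points lower from compound 3 to compound 4 (within the scatter), which is expected to stay within the scatter.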

Compound 4, a percentage reported as inhibition, at one concentration (the size of the read-out at that concentration, not a potency): 20%
For compound 4 the middle estimate is 10 percentage points below the measured one; low and high end bracket the measured number.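

In this assay, replacing hydroxymethyl with methoxy on this aromatic carbon, para to a large group, gives a number 6 percentage points higher from compound 3 to compound 4 (within the scatter). Going by these compounds alone, this is the first look at this position, since the only earlier step made its change elsewhere in the molecule, and it shows that swapping these two groups, which have the same heavy-atom count, removes the hydrogen-bond donor without moving the reading beyond the scatter. A donor at this position is therefore not shown to matter at this level of inhibition, although the whole set stays close to the floor of the read-out: the limit of < 10% in this assay, at which 2 of the 4 values shown sit.

Still open, on these data alone, is whether an amine, a carboxylic acid or a longer chain such as butoxy at this position would raise the reading beyond the scatter, or whether this position simply has little influence on the result. As far as these compounds go, the read-out also comes from a single concentration, so how compound 3 and compound 4 would compare across a range of concentrations remains unknown.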